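The source may report more compounds than this note shows. Statements on the series, on what has been measured and on what is new or still open speak of the compounds shown alone.

Measured so far:
- compound 1 `CC1=C(C(=O)O[C@@H](C)CO[N+](=O)[O-])[C@H](c2cccc3nonc23)C([N+](=O)[O-])=C(C)C1`: 156 nM
- compound 2 `CC1=C(C(=O)OC(C)CO[N+](=O)[O-])C(c2cccc3nonc23)C([N+](=O)[O-])=C(C)C1`: 1860 nM

In a functional assay (cardiac atrium) for agonist activity, with Cavia porcellus as the target (a lower number here means that less compound is needed, a higher number that more compound is needed for the effect), compound 2 gives 1860 nM, the highest of the two numbers; the nearest is compound 1 at 156 nM. Going by the values given here, the only measured step is a 12-fold higher number from compound 1 to compound 2 (1.08 log units; beyond the scatter), where the change rests on (the fact that one of compounds 1 and 2 is drawn with a defined configuration and the other without, at the place where they differ). Compound 3 `CC1=C(C(=O)O[C@@H](C)CO[N+](=O)[O-])[C@@H](c2cccc3nonc23)C([N+](=O)[O-])=C(C)C1` differs from compound 2 in the same way but with the other ring configuration: the two compounds have the same atoms and bonds; at least one stereo element is drawn with a configuration in one of them and without one in the other: 2 of 2 stereo elements differ; a stereocentre at a saturated chain carbon is drawn without a configuration in compound 2 and S in compound 3; a stereocentre at a saturated ring carbon is drawn without a configuration in compound 2 and R in compound 3. One configured isomer, compound 1, gave a large drop; for a different configured isomer the direction is open. Compound 3 is expected to stay near compound 2 or run higher, at 2500 nM (range 600 nM to 10000 nM), a step of a 1.3-fold higher number from compound 2 to compound 3 (0.13 log units; within the scatter).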

Compound 3, half-maximal effective concentration: 33700 nM
The estimate for compound 3 lay 13-fold (1.13 log units) below the measured number, outside the stated range (above it).
By their numbers in this assay, from the lowest: compound 1; then compound 2; then compound 3.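

With the chain carbon drawn S in both compounds, the ring carbon alone carries a 220-fold higher number from compound 1 to compound 3 (2.33 log units; beyond the scatter), so in this assay the configuration at this saturated ring carbon sets the number: the fact that compounds 1 and 3 differ only in the configuration as drawn. Defining both centres can also move the number the other way, as an 18-fold higher number from compound 2 to compound 3 (1.26 log units; beyond the scatter) runs opposite to the drop seen for compound 1. Compound 2, drawn without configuration, lies between the two configured isomers.

Going by these compounds alone, the role of the chain carbon stays open, since it is drawn S in both configured compounds and no step isolates it. As far as these compounds go, whether the ring configuration keeps this weight with a longer chain in place of the present one is also open.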